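This account rests on a few compounds, and the source may have more. Where it says the series, first, only, none or still open, it means among the compounds named here.

Of the compounds shown here, three built on one shared core have so far been measured in an ADME assay on cells (T-cell, Mus musculus, strain BALB/c) for cytotoxicity, read by MTT assay, with a stated time of 48 h; on this read-out higher numbers stand for lower toxicity in this test and lower numbers for higher toxicity in this test. Compound 1 `COC(=O)c1c(F)cccc1OC(=O)COc1cc(O)c2c(=O)cc(-c3ccccc3)oc2c1` gives 319000 nM. Compound 2 `COC(=O)c1c(Cl)cc(Cl)cc1OC(=O)COc1cc(O)c2c(=O)cc(-c3ccccc3)oc2c1` gives 345000 nM, and compound 3 `COC(=O)c1cccc(C)c1OC(=O)COc1cc(O)c2c(=O)cc(-c3ccccc3)oc2c1` gives 299000 nM. Among these three numbers compound 1 stands second highest; its nearest neighbour is compound 3 and its furthest is compound 2, and both gaps lie within the scatter, so the three cannot be ranked against each other. Compound 4 `COC(=O)c1c(Cl)cccc1OC(=O)COc1cc(O)c2c(=O)cc(-c3ccccc3)oc2c1` differs from compound 1 by chloro in place of fluoro on an aromatic carbon. Among the measured compounds shown here, the one measured step that speaks to such a change is a 1.1-fold lower number from compound 1 to compound 3 (0.03 log units; within the scatter), where a whole substituted ring was exchanged for another and the number stayed within the scatter. A single halogen swap on the same ring is therefore expected to do no more, and the step from compound 1 to compound 4 is expected to be a 1.0-fold higher number from compound 1 to compound 4 (0.01 log units; within the scatter). Compound 4 is thus estimated at 325000 nM, with a range from 200000 nM to 530000 nM.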

Compound 4, half-maximal cytotoxic concentration: 366000 nM
Compound 4: middle estimate off by 1.1-fold (0.05 log units), on the low side; low and high end bracket the measured number.
By their numbers in this assay, from the lowest: compounds 3, 1, 2 and 4 (each within the scatter of the next).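

In this assay, the direct exchange of the two halogens at this ring position gives a 1.1-fold higher number from compound 1 to compound 4 (0.06 log units; within the scatter), so chloro and fluoro cannot be told apart here. Hydrogen in place of chloro on an aromatic carbon gives a 1.1-fold higher number from compound 2 to compound 4 (0.03 log units; within the scatter), and exchanging one whole substituted ring for another gives a 1.2-fold higher number from compound 3 to compound 4 (0.09 log units; within the scatter), so these changes also stay within the scatter. No information is available to explain why the number holds so steady across these changes.

Across these compounds, this ring carries only fluoro, chloro, methyl and hydrogen, so it remains open whether an amine at the same position would move the number beyond the scatter. As far as these compounds go, the methoxycarbonyl group is present in all four, so the effect of a carboxylic acid in its place also remains open.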